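Methyl to fluoro on the core of compound 1

This account rests on a few compounds, and the source may have more. Where it says the series, first, only, none or still open, it means among the compounds named here.

Measured so far:
compound 1, `Cc1ccc2oc(-c3ccc(NC(=O)CN4CCN(CCCN(C)C)CC4)c(C)c3)nc2c1`, 12700 nM
compound 2, `Cc1ccc2oc(-c3ccc(NC(=O)CN4CCN(CCN(C)C)CC4)c(C)c3)nc2c1`, 7240 nM

In a functional assay on HT-29 cells (Homo sapiens) for cytotoxicity, read by MTT assay, with a stated time of 24 h (a higher number here means a weaker inhibitor, a lower number a stronger inhibitor), compound 1 stands highest of the two numbers, though its step to compound 2 is only a 1.8-fold lower number from compound 1 to compound 2 (0.24 log units; within the scatter), which lies within the scatter. Compound 3, `Cc1cc(-c2nc3cc(F)ccc3o2)ccc1NC(=O)CN1CCN(CCCN(C)C)CC1`, is unmeasured. It differs from compound 1 by fluoro in place of methyl on an aromatic carbon. Within the data shown here, the only measured step, the one from compound 1 to compound 2, concerns the chain rather than the ring carbon where this change sits, so no measured step bears on it. With nothing to go on beyond the structure, compound 3 is expected to stay near compound 1, that is, an estimated step of a 1.1-fold lower number from compound 1 to compound 3 (0.02 log units; within the scatter) in this assay, which is none beyond the scatter. The estimated value for compound 3 is 12000 nM, with a range from 4000 nM to 35000 nM.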

Compound 3, half-maximal inhibitory concentration: 6700 nM
Compound 3: middle estimate off by 1.8-fold (0.25 log units), on the high side; the measured number falls inside the stated range.
By their numbers in this assay, from the lowest: compounds 3, 2 and 1 (each within the scatter of the next).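

In this assay the swap of 5-methyl-1,3-benzoxazol-2-yl for 5-fluoro-1,3-benzoxazol-2-yl gives a 1.9-fold lower number from compound 1 to compound 3 (0.28 log units; within the scatter) and is the only step shown on an aromatic carbon, since compound 1 and compound 2 differ only in the chain. At this position, then, replacing methyl with fluoro, one heavy atom for one heavy atom, produces no difference that can be told from the scatter, so the shared core now has one reading of its own alongside the one for the chain. No measured finding on these groups bears on this result.

On these data alone, what a chloro, methoxy or nitrile group would give on this same aromatic carbon remains open. So does whether fluoro there reads the same when paired with the chain of compound 2.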